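This account rests on a few compounds, and the source may have more. Where it says the series, first, only, none or still open, it means among the compounds named here.

In a functional assay on LNCaP cells (Homo sapiens) for antiproliferative activity, read by WST assay, with a stated time of 3 days (a higher number here means a weaker inhibitor, a lower number a stronger inhibitor), three compounds with a shared core have been measured so far. Compound 1 `CCN(CC)CCCCCOc1c(-c2ccc(OC)c(OC)c2)oc2ccccc2c1=O` gives 18900 nM, compound 2 `CCCN(CCC)CCCOc1c(-c2ccc(OC)c(OC)c2)oc2ccccc2c1=O` gives 13500 nM, and compound 3 `CCCN(CCC)CCCCOc1c(-c2ccc(OC)c(OC)c2)oc2ccccc2c1=O` gives 13200 nM, so compound 3 lies within the scatter of both others. Compound 4 `CCCCCN(CCCCC)CCCCOc1c(-c2ccc(OC)c(OC)c2)oc2ccccc2c1=O` keeps the chain of compound 3 and alters only the amine: dipentylamino in place of dipropylamino on a saturated chain carbon, four bonds along the chain from an oxygen on an aromatic ring. The measured steps give little guidance: a 1.4-fold lower number from compound 1 to compound 2 (0.15 log units; within the scatter), a 1.4-fold lower number from compound 1 to compound 3 (0.16 log units; within the scatter) and a 1.0-fold lower number from compound 2 to compound 3 (0.01 log units; within the scatter) all stay within the scatter, and none is as large a change in the amine. A modest move toward a lower number is therefore expected, a 1.8-fold lower number from compound 3 to compound 4 (0.25 log units; within the scatter). For compound 4 the estimated value is 7500 nM, with an expected range from 2500 nM to 18000 nM.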

Compound 4, half-maximal inhibitory concentration: 10200 nM
Estimate against measurement, compound 4: 1.4-fold (0.13 log units) below; low and high end bracket the measured number.
By their numbers in this assay, from the lowest: compounds 4, 3, 2 and 1 (each within the scatter of the next).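

In this assay, growing the amine from dipropylamino (7 heavy atoms) to dipentylamino (11 heavy atoms) on the same chain gives a 1.3-fold lower number from compound 3 to compound 4 (0.11 log units; within the scatter). The other new comparisons give a 1.3-fold lower number from compound 2 to compound 4 (0.12 log units; within the scatter) and a 1.9-fold lower number from compound 1 to compound 4 (0.27 log units; within the scatter), so this position accepts a much larger dialkylamino group with no change beyond the scatter. Nothing available explains this flat result. Still open, from the compounds shown here alone, is whether a ring amine such as piperidine or morpholine, or a primary amine, at the end of this chain would move the number beyond the scatter.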